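The source may hold more compounds than are shown below. What is called first, only, known or untested is meant among the compounds shown, and "the series" means these compounds.

In an in vitro functional assay on cells (Fibroblast) for agonist activity at Alpha-1B adrenergic receptor (Homo sapiens) (a higher number here means that more compound is needed for the effect, a lower number that less compound is needed), the three measured compounds stand as follows, each at a limit of the assay rather than at a number:

compound 1, `Cc1n[nH]c(-c2ccccc2NCC2=NCCN2)n1`, gives < 5020 nM, a limit;
compound 2, `Cn1nccc1-c1ccccc1NCC1=NCCN1`, gives < 100000 nM, a limit;
compound 3, `Cn1cccc1-c1ccccc1NCC1=NCCN1`, gives < 100000 nM, a limit.

Compound 3 therefore sits at a limit in this assay, and so do both of its neighbours: the limit of < 100000 nM in this assay, at which 2 of the 3 values shown sit, and (the limit of < 5020 nM in this assay, at which 1 of the 3 values shown sits). For that reason the steps leading into compound 3 cannot be read: a step that the two limits leave unreadable from compound 1 to compound 3 and a step that the two limits leave unreadable from compound 2 to compound 3, and the same holds for a step that the two limits leave unreadable from compound 1 to compound 2. None of them gives a size or a direction.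

Compound 4, `CCn1cccc1-c1ccccc1NCC1=NCCN1`, is the next compound to be measured in this assay. It differs from compound 3 by methyl in place of hydrogen on a saturated chain carbon bound to an aromatic nitrogen; cut one bond further out, the change reads methyl to ethyl. Among the compounds with values here, no measured step touches this position, so no step of a known size bears on it, and nothing in the data points to a change beyond the scatter in either direction.

Compound 4 is accordingly expected to give about 30000 nM in this assay, in a range from 3000 nM to 100000 nM. The estimated step that the limit leaves unreadable from compound 3 to compound 4 is placed at no change beyond the scatter, and a result reported only as a limit is considered likely.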

Compound 4, half-maximal effective concentration: < 100000 nM
Compound 4: only a limit was reported; the forecaster's own chance of this, stated with the estimate: 60%; the middle value lies beyond the limit too.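

In this assay compound 4 gives < 100000 nM, a limit, and compound 3 also stands at a limit, so no size or direction can be read for the change from methyl to ethyl between compound 3 and compound 4. The compounds shown leave open how far any of these changes on the shared core moves agonist activity, since none has yet yielded a number.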